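Two Inactive Triazoles and a Dihydroxyphenyl Variant

The source may report more compounds than this note shows. Statements on the series, on what has been measured and on what is new or still open speak of the compounds shown alone.

The compounds share a five-membered aromatic ring with three nitrogens, carrying a 3,4,5-trimethoxyphenyl group on one side and a second aromatic ring on the other. Compound 1 `COc1cc(-n2cc(-c3ccc(N)cc3)nn2)cc(OC)c1OC` carries an aminophenyl group there. In a functional assay on MDA-MB-231 cells (Homo sapiens) for cytotoxicity, read by MTT assay (a lower number here means a stronger inhibitor, a higher number a weaker inhibitor), compound 1 gives > 10000 nM, which is a limit of the assay rather than a number. Compound 2 `COc1ccc(-c2cn(-c3cc(OC)c(OC)c(OC)c3)nn2)cc1` differs by a methoxy in place of the amino on an aromatic carbon. In this assay compound 2 gives > 10000 nM, again a limit and not a number. The step that the two limits leave unreadable from compound 1 to compound 2 therefore cannot be read, because of the limit of > 10000 nM in this assay, at which 2 of the 2 values shown sit.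

Compound 3 `COc1cc(-n2cc(-c3cc(O)cc(O)c3)nn2)cc(OC)c1OC` is the next variant: 3,5-dihydroxyphenyl in place of 4-methoxyphenyl on an aromatic carbon. Among the measured compounds shown here, no measured step bears on this change, since the only step at hand is unreadable. With both known compounds sitting at the limit, the expectation is that compound 3 stays weak in this assay, giving an estimated 15000 nM with a range from 3000 nM to 60000 nM. The expected step that the limit leaves unreadable from compound 2 to compound 3 is accordingly small, with a fair chance that only a limit is reported.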

Compound 3, half-maximal inhibitory concentration: > 10000 nM
Compound 3 gave a limit, no number (the forecaster's own chance of this, stated with the estimate: 65%); the middle value lies beyond the limit too.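

In this assay compound 3 gives > 10000 nM, which is a limit of the assay and not a number. The steps to compound 3 from compound 1 and from compound 2 therefore cannot be read, because all three compounds sit at the same limit: the limit of > 10000 nM in this assay, at which 3 of the 3 values shown sit.

The compounds shown leave open how 4-aminophenyl, 4-methoxyphenyl and 3,5-dihydroxyphenyl rank against one another in this assay.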